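Swapping Hydroxy for Carboxy on a Shared Core

The source may report more compounds than this note shows. Statements on the series, on what has been measured and on what is new or still open speak of the compounds shown alone.

The measured compounds and their values:
compound 1, `CCc1ccc2nc(C(=O)Nc3c(F)cc(-c4cccc(F)c4)cc3F)c(C)c(O)c2c1`, gives 0.74%
compound 2, `CCOc1ccc2nc(C(=O)Nc3c(F)cc(-c4cccc(F)c4)cc3F)c(C)c(O)c2c1`, gives -0.5%
compound 3, `Cc1c(C(=O)Nc2c(F)cc(-c3cccc(F)c3)cc2F)nc2ccc(OC(F)(F)F)cc2c1O`, gives 0.32%

These three numbers come from a functional assay on Hep 3B2 cells (Homo sapiens) for antiproliferative activity, read by MTT assay, with a stated time of 24 h, tested at 0.01 ug/mL; on this read-out higher numbers stand for a stronger effect at the one concentration tested and lower numbers for a weaker effect. All of them sit close to zero, and the gaps between them are small: the step of a number 1.2 percentage points lower from compound 1 to compound 2 (within the scatter) and the step of a number 0.4 percentage points lower from compound 1 to compound 3 (within the scatter) both stay within the scatter, as does the step of a number 0.8 percentage points higher from compound 2 to compound 3 (within the scatter). Compound 1 therefore cannot be set apart from compound 2 or compound 3 on these numbers; the three behave alike in this assay.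

Compound 4, `CCc1ccc2nc(C(=O)Nc3c(F)cc(-c4cccc(F)c4)cc3F)c(C)c(C(=O)O)c2c1`, has not yet been measured. It differs from compound 1 in one place: carboxy in place of hydroxy on an aromatic carbon. For the measured compounds named here, none of the measured steps touches this position; all three vary a group elsewhere on the shared core, so there is no direct guide to what a carboxy in place of hydroxy does here.

Given that every measured compound shows essentially no effect in this assay, compound 4 is expected to show a step of a number 0.2 percentage points lower from compound 1 to compound 4 (within the scatter), that is, nothing beyond the scatter. The estimate for compound 4 is 0.5%, within a range from -5% to 6%.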

Compound 4, a percentage reported as inhibition, at one concentration (the size of the read-out at that concentration, not a potency): -0.25%
Estimate against measurement, compound 4: 0.8 percentage points above; the measured number falls inside the stated range.
By their numbers in this assay, from the lowest: compounds 2, 4, 3 and 1 (each within the scatter of the next).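

In this assay, the first change shown at this position, opposite the ring nitrogen and ortho to a methyl group, puts carboxy in place of hydroxy, and the outcome is a number 1 percentage points lower from compound 1 to compound 4 (within the scatter). The earlier steps shown here varied only a group elsewhere on the shared core, so this adds something new: exchanging hydroxy for the larger carboxy does not bring any readable effect into this assay at the one concentration tested. Since compound 1 already sits close to zero, the result says little about whether the position matters, as there was almost no effect to lose, and nothing measured here bears on the reason for this outcome.

For the compounds shown here, what an amine, a methoxy group or a methyl ester would do at this same position remains open, since the only comparison here is between hydroxy and carboxy. Also open, on these data alone, is whether compound 1 and compound 4 would separate at a higher concentration, where a clear effect might give a difference large enough to read.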